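The source may hold more compounds than are shown below. What is called first, only, known or untested is meant among the compounds shown, and "the series" means these compounds.

Among the measured compounds shown here, compound 1 `Cn1nc2c(=O)n(CC3(O)CCN(Cc4ccc(-c5cccs5)cc4Cl)CC3)cnc2c1-c1ccc(CN)cc1` is one of three compounds measured in an assay on isolated protein for inhibition of ubiquitin carboxyl-terminal hydrolase 7 (Homo sapiens), with stated times of 30 min and 2 h; a lower number here means a stronger inhibitor, a higher number a weaker inhibitor; in that assay compound 1 gives 38.6 nM. Its neighbours share the same core with a furan-2-yl ring in place of the thiophene. Compound 2 `Cn1nc2c(=O)n(CC3(O)CCN(Cc4ccc(-c5ccco5)cc4Cl)CC3)cnc2c1-c1ccc(CNC2CC2)cc1` gives 54.1 nM in this assay, and compound 3 `Cn1nc2c(=O)n(CC3(O)CCN(Cc4ccc(-c5ccco5)cc4Cl)CC3)cnc2c1-c1ccc(CNC=O)cc1` gives 20.9 nM. Compound 1 thus stands second of the three numbers, within the scatter of both compound 2 and compound 3, so no order among them can be claimed. For the measured compounds named here, the only step between measured compounds, a 2.6-fold lower number from compound 2 to compound 3 (0.41 log units; beyond the scatter), concerns the amine substituent on the other end of the molecule.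

Compound 4 `Cn1cc(-c2ccc(CN3CCC(O)(Cn4cnc5c(-c6ccc(CN)cc6)n(C)nc5c4=O)CC3)c(Cl)c2)cn1` differs from compound 1 in one place: 1-methyl-1H-pyrazol-4-yl in place of thiophen-2-yl on an aromatic carbon. Going by the values given here, no measured step bears on an exchange of this aryl ring, so the expectation rests on compound 1 alone. The step of a 1.0-fold higher number from compound 1 to compound 4 (0.02 log units; within the scatter) is therefore expected to stay within the scatter. Compound 4 is expected to give 40 nM in this assay, with a range from 14 nM to 115 nM.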

Compound 4, half-maximal inhibitory concentration: 291 nM
For compound 4 the middle estimate is 7.3-fold (0.86 log units) below the measured one; the measured number lies above the stated range.
By their numbers in this assay, from the lowest: compounds 3, 1 and 2 (each within the scatter of the next, the first and the last beyond it); then compound 4.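

The aromatic carbon para to a large group and meta to the chloro group proves sensitive to the ring it carries: in this assay, 1-methyl-1H-pyrazol-4-yl in place of thiophen-2-yl gives a 7.5-fold higher number from compound 1 to compound 4 (0.88 log units; beyond the scatter), a step beyond the scatter. Among the compounds shown here, the earlier compounds offered no single-place comparison at this position, as their one step concerned the amine substituent at the other end of the molecule. No measurement shown explains this step.

The compounds shown leave open whether the N-methyl group or the pyrazole ring itself accounts for the change, a question that an unsubstituted 1H-pyrazol-4-yl ring would address. Also open, as far as these compounds go, is how a phenyl or pyridyl ring at this position, or furan-2-yl on the aminomethyl scaffold of compound 1, would compare.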